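Second chlorine on the pyridone ring of compound 3

The source may hold more compounds than are shown below. What is called first, only, known or untested is meant among the compounds shown, and "the series" means these compounds.

Of the compounds shown here, three have been tested in a functional assay for agonist activity at Bile acid receptor (Mus musculus), read by a luciferase reporter; a lower number here means that less compound is needed, a higher number that more compound is needed for the effect. Compound 1 `COc1ccccc1-c1noc(C(C)C)c1COc1ccc(/C=C/c2cccc(C(=O)O)c2)c(Cl)c1` gives 10000 nM. Compound 3 `Cc1cc(OCc2c(-c3c(Cl)ccc(=O)n3C)noc2C(C)C)ccc1-c1ccc2c(C(=O)O)cn(C)c2c1` gives 4000 nM, the lower of the two numbers, and its gap to compound 1 lies beyond the usual scatter. Compound 2 `CC(C)c1onc(-c2ccc(S(C)(=O)=O)cc2Cl)c1COc1ccc(/C=C/c2cccc(C(=O)O)c2)c(Cl)c1` reaches only the limit > 10000 nM, not a number. Going by the values given here, the one measured step, a number no lower from compound 1 to compound 2 (the limit leaves the size open), exchanged the aromatic group on the same carbon of the five-membered ring and gave no lower number, as the limit of > 10000 nM in this assay, at which 1 of the 3 values shown sits, shows. Compound 4 `Cc1cc(OCc2c(-c3c(Cl)cn(C)c(=O)c3Cl)noc2C(C)C)ccc1-c1ccc2c(C(=O)O)cn(C)c2c1` differs from compound 3 by a group of 10 heavy atoms (6 carbon, 1 nitrogen, 1 oxygen, 2 chlorine; one six-membered aromatic ring with 1 hetero atom) in place of a group of 9 heavy atoms (6 carbon, 1 nitrogen, 1 oxygen, 1 chlorine; one six-membered aromatic ring with 1 hetero atom), on an aromatic carbon, next to the ring nitrogen. Among the compounds with values here, since no measured step adds a single chlorine, a step of no change at the digits printed from compound 3 to compound 4 (within the scatter) within the scatter is expected. Compound 4 is therefore estimated at 4000 nM, between 1500 nM and 12000 nM.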

Compound 4, half-maximal effective concentration: 11000 nM
Estimate against measurement, compound 4: 2.8-fold (0.44 log units) below, and the stated range covers the measured number.
By their numbers in this assay, from the lowest: compound 3; then compounds 1 and 4 (each within the scatter of the next).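

A single added chlorine on the six-membered aromatic ring is enough to shift the result in this assay: there is a 2.8-fold higher number from compound 3 to compound 4 (0.44 log units; beyond the scatter). Going by these compounds alone, this is the first readable step at this aromatic carbon of the five-membered ring, and it shows that a change of just one atom in this group can raise the number needed. That number lies near the top of the range shown: the limit of > 10000 nM in this assay, at which 1 of the 4 values shown sits.

As far as these compounds go, whether a fluorine, a methyl group or a nitrile in place of the added chlorine would also raise the number remains open.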